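The source may hold more compounds than are shown below. What is called first, only, known or untested is meant among the compounds shown, and "the series" means these compounds.

Compound 3, `CCOC(=O)CCCCCOc1cccc(CN(C(=O)c2ccc(-c3cccc(C(C)=O)c3)cc2)C(C)C)c1`, was tested in an ADME assay on BJ cells (Homo sapiens) for cytotoxicity, read by CellTiter-Glo and resazurin assay, with a stated time of 72 h; a higher number here means that more compound is needed for the effect, a lower number that less compound is needed. In this assay compound 3 gives > 26000 nM, which is a limit of the assay rather than a number. Compound 1, `CC(=O)c1cccc(-c2ccc(C(=O)N(Cc3cccc(OCCCCCC(=O)O)c3)C(C)C)cc2)c1`, shares this outcome: in this assay compound 1 gives > 26000 nM, again a limit. Compound 2, `CC(C)N(Cc1cccc(OCCCCCC(=O)O)c1)C(=O)c1ccc(-c2cccc(OC(F)(F)F)c2)cc1`, completes the set, and in this assay compound 2 gives > 26000 nM, once more a limit. All three values therefore sit at the limit of > 26000 nM in this assay, at which 3 of the 3 values shown sit, so that no ordering among these compounds can be read.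

Compound 4, `CCOC(=O)CCCCCOc1cccc(CN(C(=O)c2ccc(-c3cccc(F)c3)cc2)C(C)C)c1`, has not yet been measured. It differs from compound 3 in one place: fluoro in place of acetyl on an aromatic carbon.

The two measured steps are the nearest guide. The step that the two limits leave unreadable from compound 1 to compound 2 also changes the group on an aromatic carbon of the outer ring, and the step that the two limits leave unreadable from compound 1 to compound 3 touches the chain end instead. Both run between two limits, and both are unreadable. Within the data shown here, the evidence thus gives no direction and no size, only that every change so far left the value at the limit.

The step expected is a step that the limit leaves unreadable from compound 3 to compound 4, that is, essentially none beyond the scatter. For compound 4 the estimated value in this assay is 30000 nM, within a range from 13000 nM to 80000 nM, with a real chance that only a limit is again reported.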

Compound 4, half-maximal effective concentration: > 26000 nM
Compound 4 gave a limit, no number (the forecaster's own chance of this, stated with the estimate: 80%); the middle value lies beyond the limit too.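

Among these compounds, compound 3 and compound 4 both end at a limit of the assay rather than a number, so the change from acetyl to fluoro gives no step that can be read. The compounds shown leave open what concentration any of them would need for the effect in this assay, because all share one limit: the limit of > 26000 nM in this assay, at which 4 of the 4 values shown sit.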